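Pyrrolidin-1-yl for dimethylamino on a carbonyl carbon

The source may hold more compounds than are shown below. What is called first, only, known or untested is meant among the compounds shown, and "the series" means these compounds.

In a toxicity assay on HEK293 cells (Homo sapiens) for inhibition, read by resazurin assay, with a stated time of 24 h (a lower number here means that less compound is tolerated, a higher number that more compound is tolerated), compound 3 (`CN(C)C(=O)c1ncc([N+](=O)[O-])n1C`) gives > 100000 nM as its reading, which is a limit and not a number. Compound 1 (`Cn1c([N+](=O)[O-])cnc1C(=O)NCc1ccc(F)cc1`) gives > 100000 nM as its reading, also a limit. Compound 2 (`COc1ccc(CNC(=O)c2ncc([N+](=O)[O-])n2C)cc1`) gives > 100000 nM as its reading, again a limit. Compound 3 therefore has no exact number to start from, and the data come down to the limit of > 100000 nM in this assay, at which 3 of the 3 values shown sit, for the whole set. Among the measured compounds shown here, the one measured step is a step that the two limits leave unreadable from compound 1 to compound 2 and so offers no size to carry over.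

Compound 4 (`Cn1c([N+](=O)[O-])cnc1C(=O)N1CCCC1`) differs from compound 3 in one place, with pyrrolidin-1-yl in place of dimethylamino on a carbonyl carbon. With nothing but limits to go on, no step beyond the usual scatter is expected in this assay and no direction can be given. The step expected is a number no higher from compound 3 to compound 4 (the limit leaves the size open) in this estimate. Compound 4 is estimated at 100000 nM with an expected range from 60000 nM to 200000 nM and will probably be reported as a limit too.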

Compound 4, half-maximal cytotoxic concentration: > 100000 nM
Compound 4: no number, only a limit; the forecaster's own chance of this, stated with the estimate: 85%; the middle value sits exactly at the limit.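

Among the compounds shown here, compound 3 and compound 4 both give limits and not numbers in this assay, so no step between them can be read. The compounds shown leave open the true half-maximal cytotoxic concentration of each and whether any change on the shared core alters it: the limit of > 100000 nM in this assay, at which 4 of the 4 values shown sit.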